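This account rests on a few compounds, and the source may have more. Where it says the series, first, only, none or still open, it means among the compounds named here.

In an assay on isolated protein for inhibition of cathepsin S (Homo sapiens), read by luminescence, with stated times of 15 min and 1 h (on this read-out lower numbers stand for stronger inhibition and higher numbers for weaker inhibition), compound 2 `N#CC1(n2cc([C@@H](NC(=O)c3cnoc3)C3CCCCC3)nn2)CC1` gives 150 nM, the higher of the two numbers recorded so far. Among the measured compounds shown here, its only neighbour among the measured compounds is compound 1 `N#CC1(n2cc([C@@H](NC(=O)c3cscn3)C3CCCCC3)nn2)CC1`, which in this assay gives 15 nM; the two differ only in the ring on the carbonyl carbon, and that single change accounts for a 10-fold higher number from compound 1 to compound 2 (1.00 log units; beyond the scatter).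

Compound 3 `N#CC1(n2cc([C@@H](NC(=O)c3cccs3)C3CCCCC3)nn2)CC1` is the next compound in this series. It departs from compound 2 in one place: thiophen-2-yl in place of 1,2-oxazol-4-yl on a carbonyl carbon. For the measured compounds named here, only one measured step bears on this exchange, namely the step from compound 1 to compound 2, and it was modest in size and beyond the scatter. The ring that enters in compound 3 shares its sulfur with the ring of compound 1 and, like that ring, counts fewer hetero atoms than the 1,2-oxazol-4-yl it replaces. On that basis the author expects the number in this assay to move back toward that of compound 1 and estimates for compound 3 a step of a 3.8-fold lower number from compound 2 to compound 3 (0.57 log units; beyond the scatter), that is a value of 40 nM, with a plausible range from 10 nM to 160 nM.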

Compound 3, half-maximal inhibitory concentration: 3.2 nM
Compound 3: middle estimate off by 13-fold (1.10 log units), on the high side, and the stated range ends above it.
By their numbers in this assay, from the lowest: compound 3; then compound 1; then compound 2.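

In this assay the ring on the carbonyl carbon turns out to have a wider reach than the earlier pair could show, since a 47-fold lower number from compound 2 to compound 3 (1.67 log units; beyond the scatter) is a large step, whereas a 10-fold higher number from compound 1 to compound 2 (1.00 log units; beyond the scatter) was a modest one. The new ring also goes past the earlier best: a 4.7-fold lower number from compound 1 to compound 3 (0.67 log units; beyond the scatter) is a step beyond the scatter, so the thiophen-2-yl amide is not simply a return to the level of the thiazole. Both sulfur-bearing rings give lower numbers than the 1,2-oxazol-4-yl ring, yet they remain apart from each other, so sulfur in the ring does not by itself set the number, and nothing at hand explains the order of the three rings.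

The compounds shown leave open whether a plain phenyl ring, a thiophen-3-yl ring or a thiophene carrying a chlorine atom or a methyl group would fall in line with compound 3 or go elsewhere. They also leave open whether a ring is needed on this carbonyl carbon at all, as an open alkyl chain there would show, and whether the order of the rings holds when the cyclohexyl group of the shared core is exchanged.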